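The compounds below may be only part of what the source reports. "The series", "measured", "known", "first", "only" and "open" are said of these compounds alone.

Compound 1 `COc1ncnc2c1c(-c1ccsc1)cn2[C@@H]1O[C@H](CO)[C@@H](O)[C@H]1O` is the reference point of this small set. In a functional assay on HL-60 cells (Homo sapiens) for antiproliferative activity, read by XTT assay, with a stated time of 72 h (a lower number here means a stronger inhibitor, a higher number a weaker inhibitor), compound 1 gives 130 nM, the lowest of the three numbers measured. Compound 2 `CN(C)c1ncnc2c1c(-c1ccsc1)cn2[C@@H]1O[C@H](CO)[C@@H](O)[C@H]1O` gives 1920 nM, and compound 3 `CSc1ncnc2c1c(-c1ccsc1)cn2[C@@H]1O[C@H](CO)[C@@H](O)[C@H]1O` gives 4590 nM. Both replacements at the methoxy-bearing aromatic carbon weaken activity: there is a 15-fold higher number from compound 1 to compound 2 (1.17 log units; beyond the scatter) and a 35-fold higher number from compound 1 to compound 3 (1.55 log units; beyond the scatter), while between the two replacements there is only a 2.4-fold higher number from compound 2 to compound 3 (0.38 log units; beyond the scatter).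

Compound 4 `COc1ncnc2c1c(-c1cc3ccccc3o1)cn2[C@@H]1O[C@H](CO)[C@@H](O)[C@H]1O` leaves the methoxy group untouched and instead changes the aryl substituent on the core: 1-benzofuran-2-yl in place of thiophen-3-yl on an aromatic carbon. None of the three measured steps bears on this position; each of them varies the methoxy group and keeps the thiophen-3-yl group fixed, so the measured data give no direct guide to how this assay responds to the larger bicyclic group.

For the measured compounds named here, with no comparable step to lean on, the expectation for compound 4 can only be anchored on compound 1 and widened accordingly. Compound 4 is estimated at 250 nM, with a range from 40 nM to 1500 nM. This estimate corresponds to an expected step of a 1.9-fold higher number from compound 1 to compound 4 (0.28 log units; within the scatter), which is to say the estimate is centred close to compound 1, and whether the new group helps or hurts beyond the scatter is left open until the measurement is known.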

Compound 4, half-maximal inhibitory concentration: 4470 nM
Compound 4: middle estimate off by 18-fold (1.25 log units), on the low side, outside the stated range (above it).
By their numbers in this assay, from the lowest: compound 1; then compound 2; then compounds 4 and 3 (each within the scatter of the next).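

In this assay, the change at this position alone, with the methoxy group kept in place, gives a 34-fold higher number from compound 1 to compound 4 (1.54 log units; beyond the scatter), so the aromatic carbon bearing thiophen-3-yl is also sensitive to what it carries, and not only the methoxy-bearing carbon varied in compounds 1 to 3. The replacement does not leave the hydrogen-bond count changed, as both groups have no donors and one acceptor, but it does bring more heavy atoms, oxygen where thiophen-3-yl has sulfur, and an added six-membered aromatic ring of carbon only, so this single step changes several things at once. No measurement shown here explains the loss of activity or ties it to any one of these differences.

The compounds shown leave open whether the loss follows the added benzo ring, the change from sulfur to oxygen, or the point of attachment, which groups such as phenyl, furan-2-yl, thiophen-2-yl or 1-benzothiophen-2-yl could separate. They also leave open whether a smaller group at this carbon, such as methyl or a bare hydrogen, would keep the activity of compound 1.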